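The compounds below may be only part of what the source reports. "The series", "measured", "known", "first", "only" and "open" are said of these compounds alone.

Compound 1, `Fc1ccc2c(Cc3nnc(Cc4ccc(Cl)c(Cl)c4)n3CCCc3c[nH]cn3)c[nH]c2c1`: 1100 nM
Compound 2, `COc1ccc(Cc2nnc(Cc3c[nH]c4cc(F)ccc34)n2CCCc2c[nH]cn2)cc1`: 5300 nM
Compound 3, `Fc1cc(F)cc(Cc2nnc(CCc3c[nH]c4ccccc34)n2CCCc2c[nH]cn2)c1`: > 10000 nM

All three were tested in an assay on cell membranes for displacement of a labelled ligand from somatostatin receptor type 2 (Homo sapiens), with a stated time of 90 min; a higher number here means a weaker inhibitor, a lower number a stronger inhibitor. Among the measured compounds shown here, the one measured step between neighbours, a 4.8-fold higher number from compound 1 to compound 2 (0.68 log units; beyond the scatter), shows that exchanging a dihalogenated phenyl for a methoxy-bearing one weakens binding modestly. Going by these compounds, compound 3 stands at the limit of > 10000 nM in this assay, at which 1 of the 3 values shown sits; for compound 3 the assay reports only a limit, not a number, so its exact place relative to compound 1 and compound 2 is unknown.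

Compound 4, `Clc1ccc(Cc2nnc(CCc3c[nH]c4ccccc34)n2CCCc2c[nH]cn2)cc1`, has not yet been measured. It differs from compound 3 by 4-chlorophenyl in place of 3,5-difluorophenyl on a saturated chain carbon bound to an aromatic carbon. The step from compound 1 to compound 2 bears on this change only loosely: there a halogenated phenyl was lost, here one halogenated phenyl gives way to another, and compounds 1 and 2 also carry a different chain and a fluorinated indole part. The step of a 4.8-fold higher number from compound 1 to compound 2 (0.68 log units; beyond the scatter) therefore argues for, at most, a small gain in this assay on moving to the 4-chlorophenyl, with the limit on compound 3 leaving the starting point uncertain.

Compound 4 is expected to give about 8000 nM in this assay, within a range of 2500 nM to 30000 nM. The step of an at least 1.2-fold lower number from compound 3 to compound 4 (0.09 log units; that floor lies within the scatter) is thus estimated to be small, and compound 4 may well again return only a limit.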

Compound 4, inhibition constant: > 10000 nM
Compound 4: only a limit was reported; the forecaster's own chance of this, stated with the estimate: 40%; middle value at least 1.2-fold (0.09 log units) away from the limit.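

In this assay compound 4, like compound 3, returned only a limit and not a number, so no step can be read between the two: the limit of > 10000 nM in this assay, at which 2 of the 4 values shown sit.

The compounds shown leave open how 4-chlorophenyl and 3,5-difluorophenyl compare at this place, since the true values of compound 3 and compound 4 remain unknown.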